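A few compounds are considered here, and "the series" means these few. Any claim that something is new, unique, unknown or untested is made for them only; others in the source may bear on it.

Measured compounds:
compound 1, `Cc1nnc(SCc2cc(=O)c3ccccc3o2)o1`, > 25000 nM
compound 2, `Nc1nnc(SCc2cc(=O)c3ccccc3o2)s1`, > 25000 nM
compound 3, `Cc1nnc(SCc2coc3ccccc3c2=O)o1`, 1400 nM

The three compounds were tested in a functional assay on HeLa cells (Homo sapiens) for cytotoxicity, read by MTT assay, with a stated time of 72 h; on this read-out lower numbers stand for stronger inhibition and higher numbers for weaker inhibition. In this assay compound 1 gives > 25000 nM, which is a limit of the assay and not a number. Compound 2 likewise gives > 25000 nM in this assay, again a limit and not a number. For the measured compounds named here, compound 3 is the only one with a number: in this assay compound 3 gives 1400 nM.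

From compound 1 to compound 2 the change is 5-amino-1,3,4-thiadiazol-2-yl in place of 5-methyl-1,3,4-oxadiazol-2-yl on a sulfur. The step that the two limits leave unreadable from compound 1 to compound 2 cannot be read, because of the limit of > 25000 nM in this assay, at which 2 of the 3 values shown sit.

Compound 1 and compound 3 hold the same atoms joined differently; the difference between the two cores is not broken down here.

Compound 4, `Nc1nnc(SCc2coc3ccccc3c2=O)s1`, has not yet been measured in this assay. It differs from compound 3 by 5-amino-1,3,4-thiadiazol-2-yl in place of 5-methyl-1,3,4-oxadiazol-2-yl on a sulfur, the same change as that from compound 1 to compound 2, made at a place described in the same words.

Going by the values given here, the size of the one earlier instance of this change, a step that the two limits leave unreadable from compound 1 to compound 2, is not readable. The expectation for compound 4 therefore rests mainly on compound 3 and its value 1400 nM. Compound 4 is therefore expected to land near 2500 nM. The range expected for compound 4 runs from 700 nM to 15000 nM. The step this estimate means, a 1.8-fold higher number from compound 3 to compound 4 (0.25 log units; within the scatter), is an expectation only.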

Compound 4, half-maximal inhibitory concentration: > 25000 nM
Compound 4: a limit, no number; the forecaster's own chance of this, stated with the estimate: 25%; middle value at least 10-fold (1.00 log units) from the limit.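

In this assay compound 4 gives > 25000 nM, which is a limit of the assay and not a number. On the core of compound 3, putting 5-amino-1,3,4-thiadiazol-2-yl in place of 5-methyl-1,3,4-oxadiazol-2-yl on a sulfur gives an at least 17-fold higher number from compound 3 to compound 4 (1.25 log units; beyond the scatter), so on this core the change carries a large loss of measured strength, and the printed size is only the smallest the limit allows. This does not show that the change behaves alike on both cores, and no size can be carried from one core to the other, because the earlier step from compound 1 to compound 2 cannot be read, with compound 1, compound 2 and compound 4 all resting at the same limit: the limit of > 25000 nM in this assay, at which 3 of the 4 values shown sit.

The compounds shown include neither 5-amino-1,3,4-oxadiazol-2-yl nor 5-methyl-1,3,4-thiadiazol-2-yl, so it stays open whether the amino group or the ring sulfur accounts for the step on the core of compound 3. Also open, as far as these compounds go, is how an ethyl group or a carboxylic acid in place of the methyl on the oxadiazole would read in this assay.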